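Aryl exchange on compound 1: pyridin-3-yl to thiophen-2-yl

A few compounds are considered here, and "the series" means these few. Any claim that something is new, unique, unknown or untested is made for them only; others in the source may bear on it.

Measured in a functional assay on CHO cells for agonist activity at Alpha-2B adrenergic receptor (Homo sapiens); a lower number here means that less compound is needed, a higher number that more compound is needed for the effect:
compound 1 `CC(Oc1ccccc1-c1cccnc1)C1=NCCN1` gives 1000 nM
compound 2 `CC(Nc1ccccc1-c1ccccc1)C1=NCCN1` gives 3800 nM

Compound 1 has the lower of the two numbers in this assay; compound 2 stands clearly higher, but the two differ in more than one place, so nothing can be separated from that pair. Compound 3 `CC(Oc1ccccc1-c1cccs1)C1=NCCN1` is not yet measured. It differs from compound 1 by thiophen-2-yl in place of pyridin-3-yl on an aromatic carbon, one heteroaryl exchanged for another of similar size. Going by the values given here, no measured step shows what such an exchange does, so no change beyond the scatter is expected, and the step of a 1.2-fold higher number from compound 1 to compound 3 (0.08 log units; within the scatter) is estimated as flat. Compound 3 is expected near 1200 nM, with a range from 400 nM to 4000 nM.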

Compound 3, half-maximal effective concentration: 1000 nM
Beside the measured number, compound 3's estimate is 1.2-fold (0.08 log units) above it; low and high end bracket the measured number.
By their numbers in this assay, from the lowest: compounds 1 and 3 (each within the scatter of the next); then compound 2.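

In this assay, the series now has its first single-place step: exchanging pyridin-3-yl for thiophen-2-yl gives no change at the digits printed from compound 1 to compound 3 (within the scatter) on this aromatic carbon. At this place, a five-membered aromatic ring with sulfur therefore stands in for a six-membered aromatic ring with nitrogen without a change beyond the scatter. Nothing at hand explains this flat step.

As far as these compounds go, whether the same holds for furan-2-yl at this place remains open. So does the effect of an aryl group carrying an amine or a carboxylic acid.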